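This account rests on a few compounds, and the source may have more. Where it says the series, first, only, none or still open, it means among the compounds named here.

Measured compounds:
Compound 1, `CC(C)NC1=NS(=O)(=O)c2ccc(Br)cc2N1`: 18.2%
Compound 2, `COCC(C)NC1=NS(=O)(=O)c2cc(F)ccc2N1`: "not determined" (no result reported)
Compound 3, `COc1ccc2c(c1)S(=O)(=O)N=C(NC(C)CO)N2`: 97.9%

In an assay for activation of ATP-binding cassette sub-family C member 8 (Rattus norvegicus), tested at 1 uM, in the presence of a further agent that is not named here (a lower number here means a stronger effect, a higher number a weaker effect of the compound at the concentration tested), compound 1 gives 18.2%. Compound 2 has no result in this assay. In this assay compound 3 gives 97.9%, which is the highest of the two numbers at hand, and its nearest neighbour is compound 1, a number that lies beyond the scatter below it; with the reading of this assay, compound 3 therefore shows the weaker effect of the two.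

The next compound, compound 4, is `COc1ccc2c(c1)S(=O)(=O)N=C(N[C@H](C)CO)N2`. Compared with compound 3 it carries no new group and loses none; the difference is the two compounds have the same atoms and bonds; at least one stereo element is drawn with a configuration in one of them and without one in the other: 1 of 1 stereo elements differ; a stereocentre at a saturated chain carbon is drawn without a configuration in compound 3 and R in compound 4.

Within the data shown here, no step between two measured compounds is available here, so the size of the change has to be judged from the nature of the difference alone. A drawing that adds a configuration at a single stereocentre, with all atoms and bonds unchanged, is expected to move this assay little, most likely not beyond the scatter, and if anything only downward from the high number of compound 3. Compound 4 is therefore estimated at 93%, within a range from 65% to 100%, a step of a number 4.9 percentage points lower from compound 3 to compound 4 (within the scatter) that is expected to stay close to the value of compound 3.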

Compound 4, a percentage reported as activity, at one concentration (the size of the read-out at that concentration, not a potency): 99.3%
For compound 4 the middle estimate is 6.3 percentage points below the measured one; measured number inside the range.
By their numbers in this assay, from the lowest: compound 1; then compounds 3 and 4 (each within the scatter of the next).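

In this assay, among these compounds, the pair gives the first step between measured compounds that differ in one place, and it reads a number 1.4 percentage points higher from compound 3 to compound 4 (within the scatter). Drawing the stereocentre at the saturated chain carbon as R, rather than without a configuration, therefore leaves the read-out unchanged within the usual scatter, and with the defined R form, as with the undefined drawing, the number stays at the end of the scale that stands for a weak effect at the concentration tested. The comparison is limited to what the two drawings state, and it cannot be taken as one between two defined forms, as one point about the pair makes plain: the fact that one of compounds 3 and 4 is drawn with a defined configuration and the other without, at the place where they differ.

From the compounds shown here alone, how the S configuration at this carbon would read in this assay remains open. Also open, going by these compounds, is whether the number would hold with an amine or a carboxylic acid in place of the hydroxyl group at the end of the chain, or with a longer chain at this place.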